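A Change at the Amide Nitrogen of Compound 2

The source may report more compounds than this note shows. Statements on the series, on what has been measured and on what is new or still open speak of the compounds shown alone.

Compound 1 `CCCOc1ccc2cc(C(=O)NCCO)c(=O)oc2c1` gives 22600 nM in a functional assay on HeLa cells (Homo sapiens) for cytotoxicity, read by MTT assay, with a stated time of 72 h; on this read-out lower numbers stand for stronger inhibition and higher numbers for weaker inhibition.
Compound 2 `O=C(NCCO)c1cc2ccc(OCc3ccccc3)cc2oc1=O` gives 14200 nM in this assay.
Compound 3 `O=C(NCCO)c1cc2ccc(OCc3ccc([N+](=O)[O-])cc3)cc2oc1=O` gives 6890 nM in this assay.

Among these three numbers compound 2 holds the second highest. Its nearest neighbour is compound 1: a 1.6-fold lower number from compound 1 to compound 2 (0.20 log units; within the scatter). Its furthest is compound 3: a 2.1-fold lower number from compound 2 to compound 3 (0.31 log units; beyond the scatter). The remaining pair shows a 3.3-fold lower number from compound 1 to compound 3 (0.52 log units; beyond the scatter).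

Compound 4 `O=C(NO)c1cc2ccc(OCc3ccccc3)cc2oc1=O` differs from compound 2 in one place: hydroxy in place of 2-hydroxyethyl on an amide-type nitrogen. Every measured step in this set changes the group on the saturated chain carbon bound to an oxygen on the aromatic ring, or a substituent on that group; not one of them touches the amide-type nitrogen. There is therefore no measured step that bears directly on this change, and the shown numbers give no ground for expecting a shift in either direction beyond the scatter. The best expectation for compound 4 in this assay is a number close to that of compound 2, and the step is estimated as a 1.0-fold lower number from compound 2 to compound 4 (0.01 log units; within the scatter). Given that nothing measured speaks to this position, the expected value for compound 4 is 14000 nM, with a deliberately wide range from 4000 nM to 45000 nM.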

Compound 4, half-maximal inhibitory concentration: 31800 nM
Compound 4: middle estimate off by 2.3-fold (0.36 log units), on the low side; the range from low to high includes it.
By their numbers in this assay, from the lowest: compound 3; then compounds 2, 1 and 4 (each within the scatter of the next, the first and the last beyond it).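

In this assay, the amide-type nitrogen now has a measured step of its own: hydroxy in place of 2-hydroxyethyl gives a 2.2-fold higher number from compound 2 to compound 4 (0.35 log units; beyond the scatter). This shows that a change at this position can move the number beyond the scatter, though only modestly, and here the move is towards weaker inhibition, while every earlier step concerned the group on the saturated chain carbon bound to an oxygen on the aromatic ring. The two groups have the same counts of hydrogen-bond donors and acceptors and differ in heavy atoms, 3 against 1, but no measurement shown here explains the shift.

A single step cannot say whether the shift follows the length of the group on the nitrogen or the hydroxy sitting directly on it; a longer chain such as 3-hydroxypropyl, or a 2-aminoethyl group, would help to separate the two. On these data alone, it also remains open whether the same swap would have a similar effect with the 4-nitrophenyl group of compound 3 in place of the phenyl group of compound 2.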